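The compounds below may be only part of what the source reports. "The series", "measured", "known", "first", "only" and "open" are said of these compounds alone.

Compound 1 `O=C(CC1c2ccccc2N=C(SCCCCCN2CCCC2)N1c1ccc(-c2ccc(F)cc2)cc1)NCc1ccc(F)cc1` and compound 2 `O=C(CC1c2ccccc2N=C(SCCCCCN2CCCC2)N1c1ccccc1)NCc1ccc(F)cc1` share one core and differ in a single place: compound 1 carries 4-fluorophenyl in place of hydrogen on an aromatic carbon. In an assay on cells for inhibition of Voltage-dependent T-type calcium channel subunit alpha-1I (Homo sapiens), read by patch clamp (on this read-out lower numbers stand for stronger inhibition and higher numbers for weaker inhibition), compound 1 gives 19800 nM, and compound 2 gives 664000 nM; the step is a 34-fold lower number from compound 2 to compound 1 (1.53 log units; beyond the scatter). Compound 3 `CN(C)CCCCCSC1=Nc2ccccc2C(CC(=O)NCc2ccc(F)cc2)N1c1ccccc1` differs from compound 2 by dimethylamino in place of pyrrolidin-1-yl on a saturated chain carbon, five bonds along the chain from a sulfur. In this assay compound 3 gives "not active" (no number reported), so no single number stands for it, and the gap between compound 2 and compound 3 cannot be counted. Compound 4 `CN(C)CCCCCSC1=Nc2ccccc2C(CC(=O)NCc2ccc(F)cc2)N1c1ccc(-c2ccc(F)cc2)cc1` remains to be measured; it differs from compound 3 by 4-fluorophenyl in place of hydrogen on an aromatic carbon, the same change as from compound 2 to compound 1, at the same place. Within the data shown here, the only measured guide for a change of this kind is a 34-fold lower number from compound 2 to compound 1 (1.53 log units; beyond the scatter), a single pair. In this assay a lowering of roughly that size is expected from compound 3 to compound 4; the starting point is the weaker one, as compound 3 has no number while compound 2 has one. Compound 4 is accordingly expected to give about 60000 nM, with a range from 15000 nM to 300000 nM.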

Compound 4, half-maximal inhibitory concentration: 960 nM
The estimate for compound 4 lay 63-fold (1.80 log units) above the measured number; the whole stated range lies above it.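

In this assay, dimethylamino in place of pyrrolidin-1-yl on the core of compound 1, which carries the 4-fluorophenyl, gives a 21-fold lower number from compound 1 to compound 4 (1.31 log units; beyond the scatter) and this large step lies beyond the scatter. On the core of compound 2 the same change leads to compound 3, reported as not active with no number, so the steps that involve compound 3 cannot be read. The change therefore has one readable size on one core only: the report for compound 3 gives no sign of a similar lowering on the core without the 4-fluorophenyl, but without a number it does not show how far the two cores differ.

Going by these compounds, it remains open whether piperidin-1-yl or diethylamino on the same chain would read closer to dimethylamino or to pyrrolidin-1-yl. Also open, on these data alone, is whether a 4-chlorophenyl or a plain phenyl in place of the 4-fluorophenyl would preserve the reading of compound 4. Nothing given here bears on the cause of the size of this step.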